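Swapping a butylamino chain for an imidazole ring

The source may report more compounds than this note shows. Statements on the series, on what has been measured and on what is new or still open speak of the compounds shown alone.

Measured compounds:
Compound 1, `CCCNc1cc(-c2ccccc2)nc2cc(OC)cc(OC)c12`, 13100 nM
Compound 2, `CCCCNc1cc(-c2ccccc2)nc2cc(OC)cc(OC)c12`, 19600 nM

In a functional assay on A549 cells (Homo sapiens) for inhibition, read by MTT assay, with a stated time of 72 h (on this read-out lower numbers stand for stronger inhibition and higher numbers for weaker inhibition), compound 1 gives 13100 nM and compound 2 gives 19600 nM. For the measured compounds named here, the only step between them, a 1.5-fold higher number from compound 1 to compound 2 (0.17 log units; within the scatter), leaves the two numbers inside the scatter of each other, so compound 2 stands alongside compound 1 rather than apart from it. Compound 3, `COc1cc(OC)c2c(-n3ccnc3)cc(-c3ccccc3)nc2c1`, has not yet been measured. It differs from compound 2 in one place: 1H-imidazol-1-yl in place of butylamino on an aromatic carbon. Going by the values given here, no measured step touches this kind of exchange; the step from compound 1 to compound 2 only lengthens a chain and says nothing about replacing the whole chain and its nitrogen-hydrogen donor with an aromatic ring. The expectation is therefore uncertain and centred near the present numbers, with a step of a 1.3-fold lower number from compound 2 to compound 3 (0.12 log units; within the scatter) in this assay anticipated. Compound 3 is estimated at 15000 nM, within a wide range from 4000 nM to 60000 nM.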

Compound 3, half-maximal inhibitory concentration: > 100000 nM
Compound 3 gave a limit, no number; the forecaster's own chance of this, stated with the estimate: 15%; middle value at least 6.6-fold (0.82 log units) away from the limit.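

In this assay, compound 3 gives > 100000 nM, which is a limit of the assay and not a number. Exchanging the chain for 1H-imidazol-1-yl on this aromatic carbon, opposite the ring nitrogen, produces an at least 5.1-fold higher number from compound 2 to compound 3 (0.70 log units; beyond the scatter), and the same exchange starting from the shorter chain produces an at least 7.6-fold higher number from compound 1 to compound 3 (0.88 log units; beyond the scatter). This position is therefore not indifferent to what it carries: changing the chain length kept the numbers within the scatter, whereas this exchange moves them beyond it, even though butylamino and 1H-imidazol-1-yl each hold 5 heavy atoms.

Going by these compounds, it remains open whether the change follows from losing the amine hydrogen or from introducing an aromatic ring, a question that pyrrolidin-1-yl or benzylamino on the same carbon could help separate. On these data alone, the full size of both steps also remains unknown.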